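A few compounds are considered here, and "the series" means these few. Any claim that something is new, unique, unknown or untested is made for them only; others in the source may bear on it.

Measured so far in a physicochemical assay for solubility, read by LC-MS, in phosphate buffer, with a stated time of 24 h, at pH 7.4; a lower number here means a less soluble compound, a higher number a more soluble compound:
Compound 1, `O=C(Nc1ccccc1)c1cnc(NCc2c(F)ccc3c2CCO3)n2cnnc12`: < 1000 nM
Compound 2, `Cc1ncccc1-c1cnc(NCc2c(F)ccc3c2CCO3)c2n[nH]c(=O)n12`: < 2000 nM

The value for compound 1 is a limit of this assay and not a number; it sits at the limit of < 1000 nM in this assay, at which 1 of the 2 values shown sits. The value for compound 2 is likewise a limit, sitting at the limit of < 2000 nM in this assay, at which 1 of the 2 values shown sits. Among the measured compounds shown here, compound 1 therefore stands only at a limit, and the one further value shown is a limit as well, so no step between measured compounds can be read from this pair, and the two values say only that both compounds fall at the low end of what this assay reports.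

Compound 3, `O=C1CC2(CC2)CN1c1cnc(NCc2c(F)ccc3c2CCO3)n2cnnc12`, has not yet been measured in this assay. It differs from compound 1 in one place: a group of 8 heavy atoms (6 carbon, 1 nitrogen, 1 oxygen; one three-membered non-aromatic ring of carbon only, one five-membered non-aromatic ring with 1 hetero atom) in place of a group of 9 heavy atoms (7 carbon, 1 nitrogen, 1 oxygen; one six-membered aromatic ring of carbon only), on an aromatic carbon. For the measured compounds named here, no measured step offers a precedent for this change. The step is expected to be an at least 4.0-fold higher number from compound 1 to compound 3 (0.60 log units; beyond the scatter), a rise beyond the usual scatter, though with the starting point a limit rather than a number the size remains uncertain. Compound 3 is expected to give about 4000 nM in this assay, within a range from 700 nM to 25000 nM.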

Compound 3, solubility: 130000 nM
Estimate against measurement, compound 3: 33-fold (1.51 log units) below; measured number outside the range, above it.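

In this assay, the place on an aromatic carbon of the shared core proves able to move the read-out strongly: the group with a three-membered non-aromatic ring of carbon only and a five-membered non-aromatic ring with 1 hetero atom, put in place of phenylcarbamoyl, gives an at least 130-fold higher number from compound 1 to compound 3 (2.11 log units; beyond the scatter). The size of this step has no upper end in these data because the value of compound 1 is a limit and not a number: the limit of < 1000 nM in this assay, at which 1 of the 3 values shown sits. Compound 3 is also the only compound shown that has a number rather than a limit, and compared with compound 1 it has lost the six-membered aromatic ring and the hydrogen-bond donor while keeping 1 hydrogen-bond acceptor.

This one step removes the aromatic ring and the hydrogen-bond donor together, and the compounds shown do not separate the two. From the compounds shown here alone, it stays open how a plain pyrrolidinone without the three-membered ring would read at this place, or a phenylcarbamoyl group with a methyl in place of the amide hydrogen.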